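Series notes: alkyne-linked amides as mGlu5 positive modulators

This account rests on a few compounds, and the source may have more. Where it says the series, first, only, none or still open, it means among the compounds named here.

Measured compounds:
compound 1, `O=C(NC1CCCC1)c1ccc(C#Cc2ccccc2)nc1`, 19 nM
compound 2, `O=C1c2ccc(C#Cc3ccccc3Cl)nc2CCN1C1CCCC1`, 393 nM

In a functional assay on HEK293 cells for positive allosteric modulation of metabotropic glutamate receptor 5 (Homo sapiens), read by FLIPR and calcium flux (on this read-out lower numbers stand for an effect already at smaller amounts and higher numbers for an effect only at larger amounts of compound), compound 1 gives 19 nM. Compound 2 carries a different core and a 2-chlorophenyl on the alkyne; in this assay compound 2 gives 393 nM, the higher of the two numbers, and the gap to compound 1 lies beyond the scatter. The two compounds differ in more than one place, so nothing can be separated out from that pair.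

Compound 3, `COc1cccc(C#Cc2ccc3c(n2)CCN(C2CCCC2)C3=O)c1`, keeps the core of compound 2 and changes only the aryl end of the alkyne: 3-methoxyphenyl in place of 2-chlorophenyl on a triple-bonded carbon. Within the data shown here, no measured pair isolates this change, and the only comparison at hand, compound 1 against compound 2, mixes core and aryl changes. The expectation is therefore loose: a moderate shift toward lower numbers is estimated for the step from compound 2 to compound 3, a 2.0-fold lower number from compound 2 to compound 3 (0.29 log units; within the scatter), but a result within the scatter would not be surprising. For compound 3 in this assay the estimate is 200 nM, with a range from 50 nM to 800 nM.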

Compound 3, half-maximal effective concentration: 462 nM
Estimate against measurement, compound 3: 2.3-fold (0.36 log units) below, and the stated range covers the measured number.
By their numbers in this assay, from the lowest: compound 1; then compounds 2 and 3 (each within the scatter of the next).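

Among these compounds, the swap to 3-methoxyphenyl in place of 2-chlorophenyl on a triple-bonded carbon gives a 1.2-fold higher number from compound 2 to compound 3 (0.07 log units; within the scatter) in this assay, and this is the first comparison that isolates a single place. On the shared core of compound 2 and compound 3, the two aryl ends cannot be told apart in this read-out, even though 3-methoxyphenyl carries a hydrogen-bond acceptor and 2-chlorophenyl carries none. Nothing measured alongside these compounds bears on why the step is this small.

Compound 1 differs from compound 2 in more than one place, so the gap between them remains unassigned as between the core and the aryl end. Also open, as far as these compounds go, is how this core reads with a different group at the end of the alkyne, such as a pyridyl ring in place of the phenyl, or a nitrile or a fluorine on the phenyl.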